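Amino for Hydroxy in a Small Antiproliferative Scaffold

A few compounds are considered here, and "the series" means these few. Any claim that something is new, unique, unknown or untested is made for them only; others in the source may bear on it.

The account starts from compound 1 `Cc1cc(OCc2ccccn2)c2cccc(O)c2n1`, tested in a functional assay on MCF7 cells (Homo sapiens) for antiproliferative activity, with a stated time of 24 h; a higher number here means a weaker inhibitor, a lower number a stronger inhibitor. In this assay compound 1 gives 160 nM. Two much larger compounds share the core of compound 1: compound 2 `CC1=C(/C=C/C(C)=C/C=C/C(C)=C/C(=O)NCC(=O)N(C)c2ccc(Cl)c(COc3cccc4c(OCc5ccccn5)cc(C)nc34)c2Cl)C(C)(C)CCC1` and compound 3 `CNC(=O)c1ccc(/C=C/C(=O)NCc2cn(-c3ccc(Cl)c(COc4cccc5c(OCc6ccccn6)cc(C)nc45)c3Cl)nn2)cc1`. In this assay compound 2 gives 65000 nM, and compound 3 gives 91000 nM. Compound 1 therefore stands lowest of the three numbers; compound 2 is the nearest to it and compound 3 the furthest, and both gaps lie beyond the scatter.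

The change that leads to compound 4 `Cc1cc(OCc2ccccn2)c2cccc(N)c2n1` is a small one: amino in place of hydroxy on an aromatic carbon. Among the measured compounds shown here, no two measured compounds differ in only one place, so there is no measured step that tells how this assay answers an exchange of this kind; the two large compounds show only that their values sit far above that of compound 1. For compound 4 the exchange is expected to give a step of a 2.5-fold higher number from compound 1 to compound 4 (0.40 log units; beyond the scatter) of modest size, more likely toward a higher number than a lower one, and quite possibly none beyond the scatter. Compound 4 is accordingly estimated at 400 nM, with a range from 100 nM to 2000 nM.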

Compound 4, half-maximal inhibitory concentration: 860 nM
Compound 4: the middle estimate sits 2.2-fold (0.33 log units) below what was measured; the measured number falls inside the stated range.
By their numbers in this assay, from the lowest: compound 1; then compound 4; then compounds 2 and 3 (each within the scatter of the next).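

Among the compounds shown here, the step of a 5.4-fold higher number from compound 1 to compound 4 (0.73 log units; beyond the scatter) is the first exchange at a single place to be read in this assay, and it shows that this aromatic carbon is not indifferent to the group it carries. Hydroxy and amino match in the counts of heavy atoms, hydrogen-bond donors and hydrogen-bond acceptors, and neither carries a net charge, yet the modest step lies beyond the scatter, so those shared counts do not make the two groups interchangeable here. No measurement shown offers an explanation for the difference between the two groups.

As far as these compounds go, whether a methoxy group, a fluorine atom or a bare hydrogen on this aromatic carbon would give a number nearer that of compound 1 or that of compound 4 remains open. Also open, from the compounds shown here alone, is whether a methylamino group or an acetamide at the same place would follow amino, and whether the exchange would give a step of similar size with other groups elsewhere on the core of compound 1.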